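The compounds below may be only part of what the source reports. "The series", "measured", "known", "first", "only" and "open" are said of these compounds alone.

Measured in a functional assay on SK-BR-3 cells (Homo sapiens) for inhibition, with a stated time of 72 h; a lower number here means a stronger inhibitor, a higher number a weaker inhibitor:
- compound 1 `CCCCCC/C=C\CCCCCCCCOC[C@H]1NC[C@H](O)[C@@H]1O`: 6000 nM
- compound 2 `CCCCCC/C=C/CCCCCCCCOC[C@H]1NC[C@H](O)[C@@H]1O`: 10000 nM

Compound 2 gives 10000 nM and cannot be separated from compound 1, as a 1.7-fold higher number from compound 1 to compound 2 (0.22 log units; within the scatter) shows. Compound 3 `CCCCCCCCCCCCCCCCOC[C@H]1NC[C@H](O)[C@@H]1O` is next, with a group of 8 heavy atoms (8 carbon; no ring) in place of a group of 8 heavy atoms (8 carbon; no ring), on a saturated chain carbon, eight bonds along the chain from an oxygen on a saturated carbon. Octyl enters on a saturated chain carbon, eight bonds along the chain from an oxygen on a saturated carbon, and the double bond leaves with the outgoing group. Going by the values given here, the only measured step bearing on this is a 1.7-fold higher number from compound 1 to compound 2 (0.22 log units; within the scatter), and it rests on (the fact that compounds 1 and 2 differ only in the configuration as drawn). Among the compounds with values here, it tests the configuration of the double bond, and no measured compound lacks that bond. Within the data shown here, with only this small step as a guide, no shift beyond the scatter is expected in this assay. The expected change is a 1.3-fold lower number from compound 2 to compound 3 (0.10 log units; within the scatter). For compound 3 the estimated value is 8000 nM, with an expected range of 3000 nM to 20000 nM.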

Compound 3, half-maximal inhibitory concentration: 50000 nM
Estimate against measurement, compound 3: 6.3-fold (0.80 log units) below, outside the stated range (above it).
By their numbers in this assay, from the lowest: compounds 1 and 2 (each within the scatter of the next); then compound 3.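

In this assay the presence of the double bond matters at this position, although its configuration did not separate the earlier pair: octyl in place of the unsaturated group gives a 5.0-fold higher number from compound 2 to compound 3 (0.70 log units; beyond the scatter) and also an 8.3-fold higher number from compound 1 to compound 3 (0.92 log units; beyond the scatter) while the group keeps the same count of carbons. Both steps lie beyond the scatter, so compound 3 is the weakest of the three and the loss follows the removal of the double bond alone. Nothing available accounts for the size of this loss.

On these data alone, whether a triple bond at the same place would keep the potency of compound 1 remains open. Also open, as far as these compounds go, is how a shorter or longer chain, or an amine or a carboxylic acid in place of octyl, would compare with compound 3.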